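The compounds below may be only part of what the source reports. "The series", "measured", "known", "first", "only" and "open" are said of these compounds alone.

Compound 1 `COc1cc(O)ccc1C(=O)/C=C/c1ccc(O)c(O)c1` was tested in an assay on isolated protein for inhibition of Amine oxidase [flavin-containing] A (Homo sapiens), read by fluorescence, with a stated time of 20 min; on this read-out higher numbers stand for weaker inhibition and lower numbers for stronger inhibition. In this assay compound 1 gave only a limit, > 40000 nM, so its true potency is not pinned to a number. Compound 1 therefore sits at the limit of > 40000 nM in this assay, at which 1 of the 2 values shown sits. Compound 2 `COc1cc(O)c(C(=O)/C=C/c2ccccc2)c(O)c1`, a different arrangement of the same groups, gives a measured value in this assay, 6330 nM. Compound 3 `COc1cc(O)ccc1C(=O)/C=C/c1ccc(O)cc1` differs from compound 1 only by hydrogen in place of hydroxy on an aromatic carbon. Since compound 1 is known only as a limit, the expected step from compound 1 to compound 3 is an at least 1.6-fold lower number from compound 1 to compound 3 (0.20 log units; that floor lies within the scatter), with a slight lean toward stronger inhibition and wide uncertainty. Compound 3 is estimated at 25000 nM, within 5000 nM to 100000 nM.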

Compound 3, half-maximal inhibitory concentration: 10100 nM
For compound 3 the middle estimate is 2.5-fold (0.39 log units) above the measured one; the range from low to high includes it.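

In this assay, the hydroxy group on this aromatic carbon, ortho to a hydroxy group, is not required for measurable inhibition, and replacing it with hydrogen gives an at least 3.9-fold lower number from compound 1 to compound 3 (0.59 log units; beyond the scatter). For the compounds shown here, this is the first evidence that removing this one group strengthens inhibition. The true size of the gain remains unknown because the value for compound 1 is only a limit: the limit of > 40000 nM in this assay, at which 1 of the 3 values shown sits.

Going by these compounds, it remains open how an amine or a fluorine atom at this position would compare with hydrogen. Compound 2 differs from compound 3 in more than one place, so it cannot show how this change behaves on another core.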